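The source may hold more compounds than are shown below. What is called first, only, known or untested is meant among the compounds shown, and "the series" means these compounds.

Among the compounds with values here, compound 1 `O=C(Nc1nc2ccc(F)cc2s1)c1cn(-c2ccccc2)nc1-c1ccccc1` is the only member of the pair with a numbered result: in a functional assay on HT-29 cells (Homo sapiens) for cytotoxicity, read by MTT assay, with a stated time of 72 h (a higher number here means a weaker inhibitor, a lower number a stronger inhibitor), compound 1 gives 9800 nM. Compound 2 `Cc1ccc2nc(NC(=O)c3cn(-c4ccccc4)nc3-c3ccccc3)sc2c1` returns only a limit of the assay, > 50000 nM. The step of an at least 5.1-fold higher number from compound 1 to compound 2 (0.70 log units; beyond the scatter) is therefore read against (the limit of > 50000 nM in this assay, at which 1 of the 2 values shown sits), and its true size is open upward. Compound 3 `COc1ccc(-c2nn(-c3ccccc3)cc2C(=O)Nc2nc3ccc(F)cc3s2)cc1` is not yet measured; relative to compound 1 it carries methoxy in place of hydrogen on an aromatic carbon. Within the data shown here, the single measured step alters the substituent on the shared core and leaves the phenyl untouched, so it does not bear on this change, and no measured step shows what substitution on that phenyl does. Because compound 1 gives 9800 nM and nothing points in either direction, compound 3 is expected to move only within the scatter, a step of a 1.0-fold higher number from compound 1 to compound 3 (0.01 log units; within the scatter). The estimate for compound 3 is 10000 nM, with a range from 3000 nM to 40000 nM.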

Compound 3, half-maximal inhibitory concentration: 5560 nM
Compound 3: the middle estimate sits 1.8-fold (0.25 log units) above what was measured, and the stated range covers the measured number.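

In this assay, within the data shown here, phenyl to 4-methoxyphenyl gives a 1.8-fold lower number from compound 1 to compound 3 (0.25 log units; within the scatter), the first measured reading at this phenyl: a methoxy on an aromatic carbon, para to a large group, is accommodated without a shift beyond the scatter. The earlier step, methyl in place of fluoro on the shared core, lies beyond the scatter and ends in a limit of the assay, whereas this step has a number on both sides and can be read at its full size. No measurement shown gives a reason for this step.

One group at one place does not show how far this phenyl tolerates substitution, so an amine, a carboxylic acid or a longer chain there remains an open case. Also open, from the compounds shown here alone, is whether the methoxy would read the same with a group other than fluoro on the shared core.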